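The source may report more compounds than this note shows. Statements on the series, on what has been measured and on what is new or still open speak of the compounds shown alone.

In an assay on HEK-293T cells for antagonist activity at vitamin D3 receptor (Homo sapiens), read by a luciferase reporter, with a stated time of 24 h (on this read-out lower numbers stand for stronger inhibition and higher numbers for weaker inhibition), compound 1 `CC(C)c1onc(-c2c(Cl)cccc2Cl)c1COc1ccc(-c2nc3ccc(C(=O)O)cc3n2C)cc1` gives 7150 nM, and compound 2 `CCn1c(-c2ccc(OCc3c(-c4c(Cl)cccc4Cl)noc3C(C)C)cc2)nc2ccc(C(=O)O)cc21` gives 5760 nM. Among these two numbers compound 2 holds the lower one, though the difference to compound 1 lies within the scatter, so no order between them can be claimed. The step of a 1.2-fold lower number from compound 1 to compound 2 (0.09 log units; within the scatter) describes that comparison.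

Compound 3 `CCCn1c(-c2ccc(OCc3c(-c4c(Cl)cccc4Cl)noc3C(C)C)cc2)nc2ccc(C(=O)O)cc21` differs from compound 2 by methyl in place of hydrogen on a saturated chain carbon, two bonds along the chain from an aromatic nitrogen. Going by the values given here, the only measured step that bears on it is the one from compound 1 to compound 2, where a methyl entered on the chain one bond closer to the aromatic nitrogen and the number barely moved, as a 1.2-fold lower number from compound 1 to compound 2 (0.09 log units; within the scatter) shows. Extending the chain by one further carbon is the same kind of change, and on the evidence of that single step nothing beyond the scatter is expected in this assay in either direction. Compound 3 is therefore estimated at 5000 nM, with a likely range from 2500 nM to 12000 nM, which corresponds to an expected step of a 1.2-fold lower number from compound 2 to compound 3 (0.06 log units; within the scatter).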

Compound 3, half-maximal inhibitory concentration: 1400 nM
Beside the measured number, compound 3's estimate is 3.6-fold (0.55 log units) above it, outside the stated range (below it).
By their numbers in this assay, from the lowest: compound 3; then compounds 2 and 1 (each within the scatter of the next).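

In this assay, the chain on the aromatic nitrogen does not respond evenly to added carbon: the change from ethyl to propyl, at the saturated chain carbon two bonds along the chain from an aromatic nitrogen, gives a 4.1-fold lower number from compound 2 to compound 3 (0.61 log units; beyond the scatter) and so lies beyond the scatter, whereas the earlier change from methyl to ethyl gave a 1.2-fold lower number from compound 1 to compound 2 (0.09 log units; within the scatter) and stayed within it. Read across both changes, going from methyl to propyl gives a 5.1-fold lower number from compound 1 to compound 3 (0.71 log units; beyond the scatter) as a single step, and most of that shift appears only with the second added carbon, so chain length at this place can alter the number, though only compound 3 shows it. Nothing available here explains why the second added carbon moves the number when the first did not.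

The three compounds do not show whether a longer chain such as butyl or pentyl would continue this trend, level off or reverse it. They also leave open how a branched isopropyl group, or a propyl chain ending in a hydroxyl or an amine, would read at the same nitrogen.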